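Changing the aryl group on the sulfonamide: compound 4

The source may report more compounds than this note shows. Statements on the series, on what has been measured and on what is new or still open speak of the compounds shown alone.

Three compounds sharing one core were measured in a functional assay on cells (leukaemia cell line, Homo sapiens) for inhibition, read by sulforhodamine B assay, with a stated time of 48 h; on this read-out lower numbers stand for stronger inhibition of growth and higher numbers for weaker inhibition of growth:

Compound 1 `O=S(=O)(Nc1ccccc1Cl)c1ccc(-c2cnc(C3CC3)o2)cc1` gives 49700 nM
Compound 2 `O=S(=O)(Nc1ccc(F)c(Cl)c1)c1ccc(-c2cnc(C3CC3)o2)cc1` gives 73700 nM
Compound 3 `O=S(=O)(Nc1ccc(F)cc1F)c1ccc(-c2cnc(C3CC3)o2)cc1` gives 66100 nM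

Compound 1 has the smallest number of the three, yet the gaps to the others are within the scatter: a 1.5-fold higher number from compound 1 to compound 2 (0.17 log units; within the scatter) and a 1.3-fold higher number from compound 1 to compound 3 (0.12 log units; within the scatter), and likewise a 1.1-fold lower number from compound 2 to compound 3 (0.05 log units; within the scatter). Compound 4 `Cc1cc(Cl)ccc1NS(=O)(=O)c1ccc(-c2cnc(C3CC3)o2)cc1` differs from compound 1 by 4-chloro-2-methylphenyl in place of 2-chlorophenyl on a sulfonamide nitrogen. All three measured steps also swap the group on the sulfonamide nitrogen, and none moved beyond the scatter, so the step of a 1.1-fold higher number from compound 1 to compound 4 (0.04 log units; within the scatter) is expected to be small as well. Compound 4 is therefore estimated at 55000 nM, with a likely range from 25000 nM to 120000 nM.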

Compound 4, concentration for total growth inhibition: 54700 nM
The estimate for compound 4 lay 1.0-fold (0.00 log units) above the measured number, and the stated range covers the measured number.
By their numbers in this assay, from the lowest: compounds 1, 4, 3 and 2 (each within the scatter of the next).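

In this assay, the 4-chloro-2-methylphenyl group brings a methyl to this position, and all three new steps stay within the scatter (a 1.1-fold higher number from compound 1 to compound 4 (0.04 log units; within the scatter); a 1.2-fold lower number from compound 3 to compound 4 (0.08 log units; within the scatter); a 1.3-fold lower number from compound 2 to compound 4 (0.13 log units; within the scatter)). Four halogen-bearing phenyl groups on the sulfonamide nitrogen, one also carrying a methyl, therefore cannot be told apart here. Nothing measured here explains this.

From the compounds shown here alone, what remains open is how a group without a phenyl ring, such as a longer alkyl chain, would read at this position. An amine or a carboxylic acid on the phenyl ring is also untested among the compounds shown.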